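Moving to 3-methylphenyl on the sulfonamide nitrogen

A few compounds are considered here, and "the series" means these few. Any claim that something is new, unique, unknown or untested is made for them only; others in the source may bear on it.

In a functional assay on K562 cells (Homo sapiens) for inhibition, read by CCK-8 assay, with a stated time of 72 h (a higher number here means a weaker inhibitor, a lower number a stronger inhibitor), compound 1 (`O=C(/C=C/c1cccnc1)NCCCCCCCc1ccc(S(=O)(=O)Nc2ccccc2)cc1`) gives 56.5 nM and compound 2 (`O=C(/C=C/c1cccnc1)NCCCc1cccc(S(=O)(=O)Nc2ccccc2)c1`) gives 86.8 nM within the scatter of each other. Compound 3 (`Cc1ccc(NS(=O)(=O)c2cccc(CCCCCCNC(=O)/C=C/c3cccnc3)c2)cc1`) stands lowest of the three at 2.98 nM and lies beyond the scatter from both. Compound 4 (`Cc1cccc(NS(=O)(=O)c2cccc(CCCCCCNC(=O)/C=C/c3cccnc3)c2)c1`) has 3-methylphenyl in place of 4-methylphenyl on a sulfonamide nitrogen. Among the compounds with values here, no measured pair differs in one place only, so nothing tests this change directly. The expected step is a 1.7-fold higher number from compound 3 to compound 4 (0.22 log units; within the scatter) toward a slightly higher number, possibly within the scatter. Compound 4 is estimated at 5 nM (expected range 1.5 nM to 20 nM).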

Compound 4, half-maximal inhibitory concentration: 4.78 nM
Compound 4: the middle estimate sits 1.0-fold (0.02 log units) above what was measured, within the range that was stated.
By their numbers in this assay, from the lowest: compounds 3 and 4 (each within the scatter of the next); then compounds 1 and 2 (each within the scatter of the next).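

In this assay, within the data shown here, 3-methylphenyl in place of 4-methylphenyl on a sulfonamide nitrogen is a 1.6-fold higher number from compound 3 to compound 4 (0.21 log units; within the scatter) and provides the first one-place comparison. The step lies within the scatter, so this assay does not separate the two methylphenyl groups at this position. No data on the cause bear on this result.

Still open, as far as these compounds go, is whether this position accepts a carboxylic acid or an amine on that aryl group. Compounds 1 and 2 differ from these two in more than one place, so the effect of chain length remains unresolved.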